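The compounds below may be only part of what the source reports. "The series", "measured", "known", "first", "only" and "open" are said of these compounds alone.

Notes on the alkoxy chain, read in a functional assay on NUGC-3 cells (Homo sapiens) for antiproliferative activity, read by sulforhodamine B assay; a lower number here means a stronger inhibitor of growth, a higher number a weaker inhibitor of growth. Compound 1 `CCCCCCOc1cccc(O)c1C(=O)/C=C/c1ccc(O)cc1` gives > 30000 nM, a limit and not a number, and so stands at the limit of > 30000 nM in this assay, at which 2 of the 3 values shown sit. Compound 3 `CCCCOc1cccc(O)c1C(=O)/C=C/c1ccc(O)cc1` gives > 30000 nM, also a limit, which leaves a step that the two limits leave unreadable from compound 1 to compound 3 unreadable. Among the measured compounds shown here, compound 2 `CC(C)(C)CCOc1cccc(O)c1C(=O)/C=C/c1ccc(O)cc1` gives 3300 nM, the only true number so far, and an at least 9.0-fold higher number from compound 2 to compound 3 (0.95 log units; beyond the scatter). Compound 4 `CC(C)CCOc1cccc(O)c1C(=O)/C=C/c1ccc(O)cc1` carries isopropyl in place of butyl on a saturated chain carbon, two bonds along the chain from an oxygen on an aromatic ring, hexyloxy to isopentyloxy. For the measured compounds named here, the closest precedent is compound 2, with tert-butyl at the same place and an at least 9.0-fold lower number from compound 1 to compound 2 (0.95 log units; beyond the scatter), so a step in the same direction but probably smaller is expected, namely an at least 3.3-fold lower number from compound 1 to compound 4 (0.52 log units; beyond the scatter). The expected value for compound 4 is 9000 nM, with an estimated range of 3000 nM to 30000 nM.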

Compound 4, concentration for 50% growth inhibition: 12400 nM
For compound 4 the middle estimate is 1.4-fold (0.14 log units) below the measured one; low and high end bracket the measured number.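

The isopentyloxy chain of compound 4 is enough to give a true number where the straight chains give none (an at least 2.4-fold lower number from compound 1 to compound 4 (0.38 log units; beyond the scatter); an at least 2.4-fold lower number from compound 3 to compound 4 (0.38 log units; beyond the scatter)). Branching is also graded rather than all or nothing, as the loss of one methyl from the chain end of compound 2 shows (a 3.8-fold higher number from compound 2 to compound 4 (0.57 log units; beyond the scatter)).

Still open, on these data alone, is whether the chain tolerates anything other than plain carbon branching, such as an amine or a carboxylic acid. Compound 1 and compound 3 stand only as limits, so the step between them cannot be read: the limit of > 30000 nM in this assay, at which 2 of the 4 values shown sit.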